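The source may hold more compounds than are shown below. What is called first, only, known or untested is meant among the compounds shown, and "the series" means these compounds.

Measured so far in a functional assay on A549 cells (Homo sapiens) for cytotoxicity, read by MTT assay, with a stated time of 72 h; a lower number here means a stronger inhibitor, a higher number a weaker inhibitor:

compound 1, `COC(=O)c1sc2cc(C)ccc2c1Nc1cc(OC)c(OC)c(OC)c1`: 10.8 nM
compound 2, `COC(=O)c1sc2ncccc2c1Nc1cc(OC)c(OC)c(OC)c1`: 3850 nM
compound 3, `CCOC(=O)c1sc2cc(C)ccc2c1Nc1cc(OC)c(OC)c(OC)c1`: 7.2 nM

Compound 1 and compound 3 share one core; compound 2 carries a different core, and the difference between the two cores is not broken down here. On its own values, compound 2 gives a much higher number in this assay than either compound 1 or compound 3.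

Within the core of compound 1, the one counted change, (methyl in place of hydrogen on a saturated chain carbon bound to an oxygen next to a carbonyl group), gives a 1.5-fold lower number from compound 1 to compound 3 (0.18 log units; within the scatter).

Compound 4, `CCOC(=O)c1sc2ncccc2c1Nc1cc(OC)c(OC)c(OC)c1`, is not yet measured. Within the data shown here, it carries the core of compound 2 with methyl in place of hydrogen on a saturated chain carbon bound to an oxygen next to a carbonyl group, the same change at the same place as the one from compound 1 to compound 3.

Among the measured compounds shown here, the step from compound 2 to compound 4 in this assay is expected to be a 1.3-fold lower number from compound 2 to compound 4 (0.11 log units; within the scatter), which rests on the single earlier instance, a 1.5-fold lower number from compound 1 to compound 3 (0.18 log units; within the scatter), and on the starting value of compound 2, 3850 nM. Only one prior case exists, and it sits on another core, so the spread is kept wide.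

Compound 4 is estimated to give 3000 nM in this assay, expected to fall between 1200 nM and 8000 nM.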

Compound 4, half-maximal inhibitory concentration: 7160 nM
For compound 4 the middle estimate is 2.4-fold (0.38 log units) below the measured one, and the stated range covers the measured number.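

Methoxycarbonyl to ethoxycarbonyl gives, in this assay, a 1.9-fold higher number from compound 2 to compound 4 (0.27 log units; within the scatter). Set beside the same change on the other core, the step does not carry over at one fixed size: the same change on two cores in this assay, a 1.5-fold lower number (0.18 log units; within the scatter) from compound 1 to compound 3 and a 1.9-fold higher number (0.27 log units; within the scatter) from compound 2 to compound 4, 2.8-fold (0.45 log units) apart, beyond the scatter of two such steps

Among these compounds, each step taken alone lies within the scatter, so neither core by itself shows a firm effect of ethoxycarbonyl; what the pair shows is only that the two steps differ, and a single pair of cores gives neither a rule for a further core nor a reason for the gap.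

Open, going by these compounds, is how a longer chain, such as propoxycarbonyl, or a carboxylic acid in the same place would behave on each of the two cores in this assay. Also open, on these data alone, is whether a gap of this kind between steps recurs on a third core or stays confined to this pair.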